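Trimming the Imidazole: Expectation for Compound 4

The compounds below may be only part of what the source reports. "The series", "measured", "known", "first", "only" and "open" are said of these compounds alone.

Compound 1, `CC(C)C(Nc1nnc[nH]1)c1ccc(-c2ccc3cccc(F)c3c2)[nH]c1=O`, gives 185 nM in a functional assay on CHO cells for antagonist activity at prostaglandin E2 receptor EP3 subtype (Homo sapiens), read by cAMP accumulation; on this read-out higher numbers stand for weaker inhibition and lower numbers for stronger inhibition. Compound 2, `CC(C)C(c1ccc(-c2ccc3cccc(F)c3c2)[nH]c1=O)N1CCN/C1=N\C#N`, gives 38 nM in this assay. Compound 3, `Cc1nc(C(c2ccc(-c3ccc4cccc(F)c4c3)[nH]c2=O)C(C)C)[nH]c1C`, gives 50 nM in this assay.

Compound 3 holds the second highest of the three numbers: a 1.3-fold higher number from compound 2 to compound 3 (0.12 log units; within the scatter), while a 3.7-fold lower number from compound 1 to compound 3 (0.57 log units; beyond the scatter). Compound 4, `CC(C)C(c1ncc[nH]1)c1ccc(-c2ccc3cccc(F)c3c2)[nH]c1=O`, carries one change from compound 3: 1H-imidazol-2-yl in place of 4,5-dimethyl-1H-imidazol-2-yl on a saturated chain carbon bound to an aromatic carbon and a saturated chain carbon, so the two methyl groups of the 4,5-dimethyl-1H-imidazol-2-yl group are removed and nothing else moves. Within the data shown here, no measured step tests this removal; the known steps all exchange the whole five-membered group, and the closest one, a 1.3-fold higher number from compound 2 to compound 3 (0.12 log units; within the scatter), shows that two related five-membered groups give nearly the same number. On that basis the expected step in this assay is small, a 1.6-fold higher number from compound 3 to compound 4 (0.20 log units; within the scatter), if anything toward a slightly higher number. Compound 4 is therefore estimated at 80 nM, with a likely range from 30 nM to 250 nM.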

Compound 4, half-maximal inhibitory concentration: 33 nM
Compound 4: the middle estimate sits 2.4-fold (0.38 log units) above what was measured; the measured number falls inside the stated range.
By their numbers in this assay, from the lowest: compounds 4, 2 and 3 (each within the scatter of the next); then compound 1.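

Removing the two methyl groups costs nothing that can be told apart from the scatter in this assay: a 1.5-fold lower number from compound 3 to compound 4 (0.18 log units; within the scatter), so on this saturated chain carbon the plain 1H-imidazol-2-yl group does as well as the dimethyl one. It also stays level with the group of compound 2, a 1.2-fold lower number from compound 2 to compound 4 (0.06 log units; within the scatter), while it stands apart from the (4H-1,2,4-triazol-3-yl)amino group, a 5.6-fold lower number from compound 1 to compound 4 (0.75 log units; beyond the scatter). Nothing available gives a reason for these numbers. Still open, from the compounds shown here alone, is whether a single methyl group on the 1H-imidazol-2-yl group, or an amine or a carboxylic acid in its place, would keep the number this low.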